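Chloro for carboxypiperidinyl at the benzylic aryl ring

A few compounds are considered here, and "the series" means these few. Any claim that something is new, unique, unknown or untested is made for them only; others in the source may bear on it.

Measured so far:
compound 1, `CC(C)(C)N1C[C@@H](C(=O)Nc2nccn2Cc2ccccc2-c2ccccc2)[C@H](c2ccc(F)cc2F)C1`, 79%
compound 2, `CC(C)(C)N1C[C@@H](C(=O)Nc2nccn2Cc2ccccc2N2CCC(C(=O)O)CC2)[C@H](c2ccc(F)cc2F)C1`, 104%

In a functional assay for agonist activity at Melanocyte-stimulating hormone receptor (Homo sapiens), read by cAMP accumulation (on this read-out lower numbers stand for smaller maximal responses and higher numbers for larger maximal responses), compound 2 holds the higher of the two numbers; compound 1 sits a number 25 percentage points higher from compound 1 to compound 2 (beyond the scatter). Compound 3, `CC(C)(C)N1C[C@@H](C(=O)Nc2nccn2Cc2ccccc2Cl)[C@H](c2ccc(F)cc2F)C1`, carries the change (chloro in place of 4-carboxypiperidin-1-yl on an aromatic carbon), placed on an aromatic carbon of a six-membered aromatic ring of carbon only, ortho to a large group. Among the compounds with values here, only the step of a number 25 percentage points higher from compound 1 to compound 2 (beyond the scatter) bears on this, and compound 3 moves the other way, from the carboxypiperidinyl back to a small substituent. A drop of modest size is therefore expected: a number 24 percentage points lower from compound 2 to compound 3 (beyond the scatter). Compound 3 is estimated at 80%, in the range 60% to 100%.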

Compound 3, intrinsic activity: the largest response reached, in percent of the reference agonist's: 65%
The estimate for compound 3 lay 15 percentage points above the measured number; the measured number falls inside the stated range.
By their numbers in this assay, from the lowest: compound 3; then compound 1; then compound 2.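

In this assay, chloro on this aromatic carbon gives the lowest number of the three, and the size of the drop depends on the group it replaces: large for 4-carboxypiperidin-1-yl (a number 39 percentage points lower from compound 2 to compound 3 (beyond the scatter)) and modest for phenyl (a number 14 percentage points lower from compound 1 to compound 3 (beyond the scatter)). Both larger groups therefore stand above chloro here, an order the earlier pair could not show. Nothing measured here accounts for this order.

The compounds shown do not separate the piperidine ring from its carboxylic acid. Plain piperidin-1-yl, or a carboxylic acid on a short open chain, would address that.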